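Cyclobutylpiperazine in Place of the Piperidinylamine on the Core

The compounds below may be only part of what the source reports. "The series", "measured", "known", "first", "only" and "open" are said of these compounds alone.

Compound 3 `CN(c1nc2c(c(Nc3ccc(C(F)(F)F)cc3)n1)CCN(c1ncccc1C(F)(F)F)CC2)C1CCCNC1` holds the weaker of the two numbers obtained in a functional assay on HEK293 cells for antagonist activity at transient receptor potential cation channel subfamily V member 1 (Rattus norvegicus), read by FLIPR and calcium flux (on this read-out lower numbers stand for stronger inhibition and higher numbers for weaker inhibition), where compound 3 gives 1540 nM. Compound 2 `CCC(CC)N1CCN(c2nc3c(c(Nc4ccc(C(F)(F)F)cc4)n2)CCN(c2ncccc2C(F)(F)F)CC3)CC1` gives 185 nM in this assay. Compound 1 `NC1CCN(c2nc3c(c(Nc4ccc(C(F)(F)F)cc4)n2)CCN(c2ncccc2C(F)(F)F)CC3)C1` reaches only the limit > 5000 nM in this assay. Compound 4 `FC(F)(F)c1ccc(Nc2nc(N3CCN(C4CCC4)CC3)nc3c2CCN(c2ncccc2C(F)(F)F)CC3)cc1` differs from compound 3 in one place: 4-cyclobutylpiperazin-1-yl in place of methyl(piperidin-3-yl)amino on an aromatic carbon. The closest guide is the step of an 8.3-fold higher number from compound 2 to compound 3 (0.92 log units; beyond the scatter), as compound 2 likewise carries an alkyl group on the distal nitrogen of a piperazine; the step of an at least 3.2-fold lower number from compound 1 to compound 3 (0.51 log units; beyond the scatter) also lay beyond the scatter. A modest drop in the number is therefore expected. Compound 4 is estimated at 250 nM, within 80 nM to 800 nM. That expectation corresponds to a 6.2-fold lower number from compound 3 to compound 4 (0.79 log units; beyond the scatter).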

Compound 4, half-maximal inhibitory concentration: 161 nM
The estimate for compound 4 lay 1.6-fold (0.19 log units) above the measured number, within the range that was stated.
By their numbers in this assay, from the lowest: compounds 4 and 2 (each within the scatter of the next); then compound 3. At a limit, above all of these: compound 1.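

In this assay, an alkylated piperazine at this position holds up against a second amine: 4-cyclobutylpiperazin-1-yl in place of methyl(piperidin-3-yl)amino gives a 9.6-fold lower number from compound 3 to compound 4 (0.98 log units; beyond the scatter). The alkyl group itself matters little between these two, since cyclobutyl in place of pentan-3-yl gives a 1.1-fold lower number from compound 2 to compound 4 (0.06 log units; within the scatter). The step to the aminopyrrolidine, an at least 31-fold lower number from compound 1 to compound 4 (1.49 log units; beyond the scatter), starts from a limit: the limit of > 5000 nM in this assay, at which 1 of the 4 values shown sits.

Open, from the compounds shown here alone, is whether a smaller methyl group on the piperazine nitrogen would give a similar number. Also open, going by these compounds, is how an acetyl group there, which removes the amine, would read.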